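The source may hold more compounds than are shown below. What is called first, only, known or untested is meant among the compounds shown, and "the series" means these compounds.

Compound 1 `CC(C)CNC(=O)c1[nH]cnc1C(=O)Nc1ccc(Cl)c(Cl)c1` and compound 2 `C[C@H](NC(=O)c1[nH]cnc1C(=O)Nc1ccc(Cl)c(Cl)c1)c1ccccc1` share a core with compound 3 `COC(=O)[C@@H](C)NC(=O)c1[nH]cnc1C(=O)Nc1ccc(Cl)c(Cl)c1`, differing only in the group on the amide-type nitrogen. In a functional assay on HL-60 cells (Homo sapiens), with a stated time of 2 days (on this read-out lower numbers stand for stronger inhibition and higher numbers for weaker inhibition), compound 1 gives 14700 nM. In this assay compound 2 gives 9200 nM, and the comparison shows a 1.6-fold lower number from compound 1 to compound 2 (0.20 log units; within the scatter). For compound 3 this assay reports only a limit, > 62500 nM, which places it at the limit of > 62500 nM in this assay, at which 1 of the 3 values shown sits. Against the two smaller numbers it stands weaker: there is an at least 4.2-fold higher number from compound 1 to compound 3 (0.62 log units; beyond the scatter) and an at least 6.7-fold higher number from compound 2 to compound 3 (0.83 log units; beyond the scatter).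

Compound 4 `C[C@@H](NC(=O)c1[nH]cnc1C(=O)Nc1ccc(Cl)c(Cl)c1)C(=O)OC(C)(C)C` is not yet measured. It differs from compound 3 by tert-butyl in place of methyl on an oxygen next to a carbonyl group. Among the compounds with values here, no measured step changes the group on the ester oxygen itself; the two steps that reach compound 3 both end at the limit, so they show only that the 1-(methoxycarbonyl)ethyl group sits at the weak end. With nothing to mark a return toward the measured numbers, compound 4 is expected to remain near the limit, with an estimated step of an at least 1.0-fold lower number from compound 3 to compound 4 (0.01 log units; that floor lies within the scatter). Compound 4 is therefore estimated at 60000 nM, in the range 15000 nM to 250000 nM.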

Compound 4, half-maximal inhibitory concentration: 4600 nM
The estimate for compound 4 lay 13-fold (1.12 log units) above the measured number; the whole stated range lies above it.
By their numbers in this assay, from the lowest: compounds 4, 2 and 1 (each within the scatter of the next, the first and the last beyond it). At a limit, above all of these: compound 3.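

Replacing methyl with tert-butyl on an oxygen next to a carbonyl group gives an at least 13-fold lower number from compound 3 to compound 4 (1.13 log units; beyond the scatter), so in this assay an ester in this side chain does not by itself place a compound at the weak end. The 1-(tert-butoxycarbonyl)ethyl group cannot be told apart from 1-phenylethyl, with a 2.0-fold lower number from compound 2 to compound 4 (0.30 log units; within the scatter), but it goes beyond the scatter against isobutyl, with a 3.2-fold lower number from compound 1 to compound 4 (0.50 log units; beyond the scatter). The first of these steps has no exact size, since compound 3 stands only at a limit of the assay: the limit of > 62500 nM in this assay, at which 1 of the 4 values shown sits.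

The compounds shown leave open whether an ethyl or isopropyl ester would already give part of this step, or whether it appears only with tert-butyl. They also leave open how a free carboxylic acid or a simple primary amide in place of the ester would read.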